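The source may hold more compounds than are shown below. What is called first, only, known or untested is meant among the compounds shown, and "the series" means these compounds.

Values in a physicochemical assay for lipophilicity, read by HPLC, at pH 7.4; a higher number here means a more lipophilic compound, a lower number a more polar compound:
- compound 1 `Cc1ccccc1N1C(=O)/C(=C/c2ccc(O)c(Cl)c2)S/C1=N\CCO` gives 1.9
- compound 2 `Cc1ccccc1N1C(=O)/C(=C/c2ccc(O)c(Cl)c2)S/C1=N\CCCF` gives 3.4
- compound 3 `CCC/N=C1\S/C(=C\c2ccc(O)c(C)c2)C(=O)N1c1ccccc1C` gives 3.8

Compound 2 stands second highest of the three, with compound 3 above it and compound 1 below it, both gaps beyond the scatter. The change to compound 4 `Cc1ccccc1N1C(=O)/C(=C/c2ccc(O)c(Cl)c2)S/C1=N\C1COC1` is oxetan-3-yl in place of 3-fluoropropyl on a double-bonded nitrogen. For the measured compounds named here, only one measured step bears on it (a number 1.50 log units higher from compound 1 to compound 2 (beyond the scatter)), and it is large and beyond the scatter. That step is a different swap, fluoromethyl in place of hydroxy on a saturated chain carbon, so it guides the size only loosely. With the oxygen-bearing compound 1 low (1.9), a downward move in this assay of smaller size is expected. The expected move is (a number 0.60 log units lower from compound 2 to compound 4 (beyond the scatter)). Compound 4 is estimated at (2.8), with an expected range of 2.3 to (3.3).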

Compound 4, distribution coefficient: 2.6
Compound 4: the middle estimate sits 0.20 log units above what was measured; the range from low to high includes it.
By their numbers in this assay, from the lowest: compound 1; then compound 4; then compound 2; then compound 3.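

In this assay, on a double-bonded nitrogen, oxetan-3-yl in place of 3-fluoropropyl gives a number 0.80 log units lower from compound 2 to compound 4 (beyond the scatter), and oxetan-3-yl in place of 2-hydroxyethyl gives a number 0.70 log units higher from compound 1 to compound 4 (beyond the scatter). At this position, the four-membered ring therefore places compound 4 between the two chain-bearing compounds, with both steps beyond the scatter. Nothing measured here accounts for either step.

Still open, from the compounds shown here alone, is how an amine or a carboxylic acid on this nitrogen would read in this assay. Going by these compounds, a larger ring, such as tetrahydropyran-4-yl, is also open.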